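Trimming the Aryl Group on an Oxazole Ketone

The compounds below may be only part of what the source reports. "The series", "measured", "known", "first", "only" and "open" are said of these compounds alone.

Measured so far:
- compound 1 `NC(=O)c1cccc(-c2cnc(C(=O)CCCCCCc3ccccc3)o2)c1`: 6 nM
- compound 2 `COc1ncc(-c2cnc(C(=O)CCCCCCc3ccccc3)o2)c(OC)n1`: 26 nM

Of the compounds shown here, two have been tested in an assay (Rattus norvegicus) for inhibition of Fatty-acid amide hydrolase 1 (Homo sapiens); on this read-out higher numbers stand for weaker inhibition and lower numbers for stronger inhibition. Compound 1 `NC(=O)c1cccc(-c2cnc(C(=O)CCCCCCc3ccccc3)o2)c1` gives 6 nM in this assay, and compound 2 `COc1ncc(-c2cnc(C(=O)CCCCCCc3ccccc3)o2)c(OC)n1` gives 26 nM. Compound 1 holds the lower of the two numbers, and its gap to compound 2 is beyond the usual scatter, so compound 1 is the stronger inhibitor of this pair.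

Compound 3 `CNC(=O)c1cnc(C(=O)CCCCCCc2ccccc2)o1` has not yet been measured. Its structure differs from that of compound 1 in a single place: methylcarbamoyl in place of 3-carbamoylphenyl on an aromatic carbon. A group carrying a six-membered aromatic ring thus gives way to a much smaller group with no ring, while the count of one hydrogen-bond donor and one hydrogen-bond acceptor stays the same.

Going by the values given here, no step between measured compounds shows what such a change does here, so the expectation rests on the change alone. In this assay a move towards weaker inhibition, of a size beyond the scatter, is expected a 10-fold higher number from compound 1 to compound 3 (1.00 log units; beyond the scatter). Compound 3 is estimated to give about 60 nM, within a range from 15 nM to 300 nM.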

Compound 3, inhibition constant: 7 nM
Compound 3: the middle estimate sits 8.6-fold (0.93 log units) above what was measured, outside the stated range (below it).
By their numbers in this assay, from the lowest: compounds 1 and 3 (each within the scatter of the next); then compound 2.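

Putting methylcarbamoyl in place of 3-carbamoylphenyl, on the aromatic carbon next to the ring oxygen, gives a 1.2-fold higher number from compound 1 to compound 3 (0.07 log units; within the scatter) in this assay. At this position, then, the six-membered aromatic ring is not needed for a low number on this read-out, since a much smaller group with no ring serves equally well. Both groups carry an amide, with the same count of hydrogen-bond donors and acceptors, so this pair leaves room for the idea that the amide matters more than the ring, though a single step cannot establish that, and nothing measured here explains why the two compounds read alike.

The compounds shown leave open whether an amide is needed on this carbon at all, a question that a plain methyl group, a nitrile or a carboxylic acid in the same place would help to answer. They also leave open how much larger the group on the amide nitrogen could become, as an ethyl or benzyl amide would show.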